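A methyl added to compound 3

The compounds below may be only part of what the source reports. "The series", "measured", "known", "first", "only" and "open" are said of these compounds alone.

In a functional assay on MT4 cells (Homo sapiens) for cytotoxicity (on this read-out lower numbers stand for stronger inhibition and higher numbers for weaker inhibition), compound 3 (`N#Cc1c(N)cccc1S(=O)(=O)c1cccc(Br)c1`) reads > 200000 nM as a limit of the assay, not a number. The change to compound 4 (`Cc1cc(Br)cc(S(=O)(=O)c2cccc(N)c2C#N)c1`) is methyl in place of hydrogen on an aromatic carbon and the bromo group stays. Compound 1 (`CCCOc1cc(C)cc(S(=O)(=O)c2cccc(N)c2C#N)c1`) also carries a methyl on an aromatic carbon and gives 11000 nM as a true number. Compound 2 (`CCCCOc1cc(C)cc(S(=O)(=O)c2cccc(N)c2C#N)c1`) reads > 2000 nM as a limit of the assay. Among the measured compounds shown here, the one measured step is a step that the limit leaves unreadable from compound 1 to compound 2 and concerns a saturated chain, so it offers no size to carry over. For the measured compounds named here, with compound 1 at 11000 nM as the only guide, the expected change is an at least 4.0-fold lower number from compound 3 to compound 4 (0.60 log units; beyond the scatter) toward stronger inhibition, on thin evidence. Compound 4 is estimated at 50000 nM with an expected range of 10000 nM to 200000 nM in this measurement.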

Compound 4, half-maximal inhibitory concentration: 133000 nM
Compound 4: middle estimate off by 2.7-fold (0.42 log units), on the low side; measured number inside the range.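

In this assay, on these data alone, methyl in place of hydrogen on the aromatic carbon gives an at least 1.5-fold lower number from compound 3 to compound 4 (0.17 log units; that floor lies within the scatter), but this is only a floor set by the limit on compound 3, so the true size of the step stays unknown. Among the compounds shown here, with that methyl kept, bromo in place of propoxy gives a 12-fold higher number from compound 1 to compound 4 (1.08 log units; beyond the scatter), the first step with a real size. The step involving compound 2 cannot be read.

As far as these compounds go, it remains open how the methyl step would read in a pair with two true numbers. From the compounds shown here alone, what an amine or a carboxylic acid would give in place of the bromo group is also open.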